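Sulfonyl aryl swap: from compound 3 to compound 4

A few compounds are considered here, and "the series" means these few. Any claim that something is new, unique, unknown or untested is made for them only; others in the source may bear on it.

The series rests on a shared core bearing a sulfonyl-linked aryl group, examined in an assay for binding affinity to Neuropeptide Y receptor type 1 (Homo sapiens), read by radioligand binding; on this read-out higher numbers stand for weaker inhibition and lower numbers for stronger inhibition. Compound 1 `Nc1ccc(S(=O)(=O)c2cc(N)c3ncccc3c2)cc1` reaches only a limit in this assay, at > 10000 nM. Compound 2 `CNc1cc(S(=O)(=O)c2ccccc2)c([N+](=O)[O-])c2cccnc12` likewise gives only a limit, at > 10000 nM. For the measured compounds named here, compound 3 `COc1ccc(S(=O)(=O)c2cc(N)c3ncccc3c2[N+](=O)[O-])cc1` is the one member with a number, at 1140 nM, and so stands alone as the measured point of reference, with the limit of > 10000 nM in this assay, at which 2 of the 3 values shown sit, marking where the other two sit.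

Compound 4 `Nc1cc(S(=O)(=O)c2ccccc2Br)c([N+](=O)[O-])c2cccnc12` has not yet been tested. Against compound 3 the change is 2-bromophenyl in place of 4-methoxyphenyl on a sulfonyl sulfur. Going by the values given here, no pair of measured compounds differing in one place exists, so the size of this step cannot be read from the data. The two compounds that carry an aryl group without the methoxy substituent, compound 1 and compound 2, both reach only the limit, while compound 3 with 4-methoxyphenyl gives a number; this is taken as a loose pointer that removing the methoxy group and introducing 2-bromophenyl is more likely to weaken than to strengthen binding, beyond the scatter.

The step from compound 3 to compound 4 is therefore expected to be a loss, of about a 4.4-fold higher number from compound 3 to compound 4 (0.64 log units; beyond the scatter). Compound 4 is estimated at 5000 nM, within a range from 1500 nM to 20000 nM, with a real chance that this assay reports only a limit.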

Compound 4, inhibition constant: 234 nM
The estimate for compound 4 lay 21-fold (1.33 log units) above the measured number; measured number outside the range, below it.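

Notes on the sulfonyl aryl group: on this sulfonyl sulfur, 4-methoxyphenyl is not needed for a measured number in this assay, and the swap to 2-bromophenyl gives a 4.9-fold lower number from compound 3 to compound 4 (0.69 log units; beyond the scatter). The position therefore accepts an aryl group without the methoxy substituent and with a bromine instead, and the number moves in the stronger direction, so this aryl group is a place where the series can still change. Compound 1 and compound 2 each remain a limit of the assay and not a number, and the steps to them cannot be read: the limit of > 10000 nM in this assay, at which 2 of the 4 values shown sit.

The step exchanges one whole aryl group for another, and the shares of the incoming bromine and the outgoing methoxy group in it cannot be separated with the compounds shown. As far as these compounds go, it also remains open how this sulfonyl sulfur would respond to another aryl group, such as 2-chlorophenyl or a phenyl ring carrying a carboxylic acid, and whether the number would move further in either direction.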